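The compounds below may be only part of what the source reports. "The series", "measured", "known", "first", "only" and "open" are said of these compounds alone.

Of the compounds shown here, three sharing one core have been tested in a functional assay on MCF7 cells (Homo sapiens) for inhibition, read by MTT assay, with a stated time of 72 h; a higher number here means a weaker inhibitor of growth, a lower number a stronger inhibitor of growth. Compound 1 `CC(C)=CCC/C(C)=C/CC/C(C)=C/C(=O)NC(=N)NC(=O)C=C(C)C` carries the longest side chain and gives 23400 nM. Compound 2 `CC(C)=CC(=O)NC(=N)NC(=O)C=C(C)C` has the shortest and gives 59700 nM. Compound 3 `CC(C)=CCC/C(C)=C/C(=O)NC(=N)NC(=O)C=C(C)C`, with a chain of intermediate length, gives 41500 nM, a number within the scatter of both others, so the three cannot be told apart on these data.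

Compound 4 `CC(C)=CCC/C(C)=C/C(=O)NC(=N)NC(=O)/C=C(\C)CCC=C(C)C` differs from compound 3 in one place: 3-methylbut-2-en-1-yl in place of hydrogen on a saturated chain carbon bound to a double-bonded chain carbon. This is the same kind of change that links compound 2 to compound 3, where the step was a 1.4-fold lower number from compound 2 to compound 3 (0.16 log units; within the scatter), and the reverse of the change from compound 1 to compound 3, where the step was a 1.8-fold higher number from compound 1 to compound 3 (0.25 log units; within the scatter). Both were within the scatter, so no step beyond the scatter is expected in this assay.

For compound 4 the expected step from compound 3 is a 1.3-fold lower number from compound 3 to compound 4 (0.10 log units; within the scatter). Compound 4 is therefore estimated at 33000 nM, with a likely range from 15000 nM to 70000 nM.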

Compound 4, concentration for 50% growth inhibition: 42400 nM
For compound 4 the middle estimate is 1.3-fold (0.11 log units) below the measured one; low and high end bracket the measured number.
By their numbers in this assay, from the lowest: compounds 1, 3, 4 and 2 (each within the scatter of the next, the first and the last beyond it).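

In this assay, going by these compounds alone, the result, a 1.0-fold higher number from compound 3 to compound 4 (0.01 log units; within the scatter), shows that adding 3-methylbut-2-en-1-yl on a saturated chain carbon bound to a double-bonded chain carbon gives no difference that stands out from the scatter, even on the chain left untouched in the earlier steps. The change has now been read on two different chains, and on neither does it give a step beyond the scatter. No evidence is available that bears on this result.

From the compounds shown here alone, whether a carboxylic acid or an amine on this carbon, or a chain longer than 3-methylbut-2-en-1-yl, would give a step beyond the scatter remains open. Also open, going by these compounds, is whether the same small steps would appear on cells other than those used here.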